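The source may report more compounds than this note shows. Statements on the series, on what has been measured and on what is new or still open speak of the compounds shown alone.

Measured in a functional assay on A549 cells (Homo sapiens) for inhibition, read by MTT assay, with a stated time of 48 h; on this read-out lower numbers stand for stronger inhibition and higher numbers for weaker inhibition:

- compound 1 `Cn1c(/C=C2\SC(=O)N(CC(=O)Nc3cc(C(C)(C)C)on3)C2=O)nc2ccccc21`: 15300 nM
- compound 2 `Cn1c(/C=C2\SC(=O)N(CC(=O)Nc3nc(-c4ccccc4)cs3)C2=O)nc2ccccc21`: 11500 nM
- compound 3 `CCn1c(/C=C2\SC(=O)N(CC(=O)N3CCc4cc(OC)c(OC)cc4C3)C2=O)nc2ccccc21`: 26200 nM

Compound 1, at 15300 nM, lies within the usual scatter of both compound 2 and compound 3, so it stands among the others without a clear separation from either. The next compound to be tested is compound 4 `Cn1c(/C=C2\SC(=O)N(CC(=O)N3CCCC3)C2=O)nc2ccccc21`, which keeps the core of compound 1 and changes the group on the carbonyl carbon: pyrrolidin-1-yl in place of (5-(tert-butyl)-1,2-oxazol-3-yl)amino on a carbonyl carbon. In words, pyrrolidin-1-yl takes the place of (5-(tert-butyl)-1,2-oxazol-3-yl)amino.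

Within the data shown here, only one measured step bears directly on this position. It is a 1.3-fold lower number from compound 1 to compound 2 (0.12 log units; within the scatter), a swap of one group for another on the amide-type nitrogen, and it stays within the scatter. Among the measured compounds shown here, that step keeps the amide hydrogen, however, and no measured compound carries pyrrolidin-1-yl. Compound 3, at 26200 nM, also has no amide hydrogen, although it differs from compound 1 in more than one place. On this evidence, only a slight lean towards a higher number is expected in this assay. The expected change is a 1.3-fold higher number from compound 1 to compound 4 (0.12 log units; within the scatter), which would not go beyond the scatter. For compound 4 the estimated value is 20000 nM, with an expected range from 8000 nM to 50000 nM.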

Compound 4, half-maximal inhibitory concentration: > 50000 nM
Compound 4 ended at the assay's limit; the forecaster's own chance of this, stated with the estimate: 12%; middle value at least 2.5-fold (0.39 log units) from the limit.
By their numbers in this assay, from the lowest: compounds 2, 1 and 3 (each within the scatter of the next, the first and the last beyond it). At a limit, above all of these: compound 4.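

In this assay compound 4 gives > 50000 nM, and this value is a limit of the assay rather than a number: the limit of > 50000 nM in this assay, at which 1 of the 4 values shown sits.

Even read as a limit, it shows that this position does not tolerate every change, as pyrrolidin-1-yl in place of (5-(tert-butyl)-1,2-oxazol-3-yl)amino on the carbonyl carbon gives an at least 3.2-fold higher number from compound 1 to compound 4 (0.51 log units; beyond the scatter), whereas the only earlier step here, a 1.3-fold lower number from compound 1 to compound 2 (0.12 log units; within the scatter), stayed within the scatter. Among these compounds, this is the first single change at this position to go beyond the scatter, and it removes the amide hydrogen and the five-membered aromatic ring together.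

The compounds shown leave open which of these two losses matters, and how far compound 4 lies past the limit cannot be read. A methyl group on the amide nitrogen with the 5-(tert-butyl)-1,2-oxazol-3-yl group kept would test the amide hydrogen alone, while a cyclopentylamino group would keep that hydrogen on a non-aromatic ring and so test the aromatic ring alone.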